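A few compounds are considered here, and "the series" means these few. Any claim that something is new, unique, unknown or untested is made for them only; others in the source may bear on it.

Compound 1 `O=C(Nc1ccc(OC(F)(F)F)c(F)c1)NC1CCN(C(=O)C2(C(F)(F)F)CC2)CC1` and compound 2 `O=C(Nc1ccc(C(F)(F)F)c(F)c1)NC1CCN(C(=O)C2(C(F)(F)F)CC2)CC1` differ at one aromatic carbon. In a physicochemical assay for solubility, read by mass spectrometry, in phosphate buffer, with a stated time of 24 h, at pH 7.4 (on this read-out higher numbers stand for higher solubility and lower numbers for lower solubility), compound 1 gives 92 ug/mL and compound 2 gives 0.08 ug/mL, the lower of the two numbers. Compound 3 `O=C(Nc1ccc(C(F)(F)F)c(F)c1)NC1CCN(C(=O)[C@@H]2CCOC2)CC1` departs from compound 2 on the carbonyl carbon: oxolan-3-yl in place of 1-(trifluoromethyl)cyclopropyl on a carbonyl carbon. Among the compounds with values here, no measured step covers this change. Within the data shown here, the only one, a 1200-fold lower number from compound 1 to compound 2 (3.06 log units; beyond the scatter), is large but lies at a different place, so it shows only that one change can move this assay far. The expected step is a 130-fold higher number from compound 2 to compound 3 (2.10 log units; beyond the scatter), a large rise. The estimate for compound 3 is 10 ug/mL, with an expected range of 0.5 ug/mL to 150 ug/mL.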

Compound 3, solubility: 1.9 ug/mL
Estimate against measurement, compound 3: 5.3-fold (0.72 log units) above; the range from low to high includes it.
By their numbers in this assay, from the lowest: compound 2; then compound 3; then compound 1.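

The carbonyl carbon is a second place that moves this assay: oxolan-3-yl in place of 1-(trifluoromethyl)cyclopropyl gives a 24-fold higher number from compound 2 to compound 3 (1.38 log units; beyond the scatter), a large step beyond the scatter. The series therefore responds at this position as well as at the aromatic carbon, here with trifluoromethyl on that carbon. No measurement at hand explains the rise.

Still open, from the compounds shown here alone, is whether the step keeps its size with trifluoromethoxy on the aromatic carbon. Also open, going by these compounds, is how an amine or a carboxylic acid on the carbonyl carbon would read in this assay.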